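A few compounds are considered here, and "the series" means these few. Any claim that something is new, unique, unknown or untested is made for them only; others in the source may bear on it.

Measured so far:
compound 1 `O=C(Nc1cccc(-n2cc(-c3ccncc3)c(-c3cc(O)cc(Cl)c3)n2)c1)Nc1ccc(Cl)c(Cl)c1` — 56%
compound 2 `COc1cc(Cl)cc(-c2nn(-c3cccc(NC(=O)Nc4ccc(Cl)c(C(F)(F)F)c4)c3)cc2-c2ccncc2)c1` — 81%

In a functional assay on OVCAR-5 cells (Homo sapiens) for inhibition, read by sulforhodamine B assay, with a stated time of 48 h, tested at 1 uM (a higher number here means a weaker effect of the compound at the concentration tested, a lower number a stronger effect), compound 2 stands as the higher of the two numbers; compound 1 gives a number lower by an amount beyond the scatter. Compound 3 `COc1cc(Cl)cc(-c2nn(-c3cccc(NC(=O)Nc4ccc(Cl)c(Cl)c4)c3)cc2-c2ccncc2)c1` differs from compound 2 by chloro in place of trifluoromethyl on an aromatic carbon. Among the measured compounds shown here, no measured pair isolates this change. Compound 1 carries the same 3,4-dichlorophenyl group, yet differs from compound 3 in a second place too, so its value is only a loose pointer. The step of a number 11 percentage points lower from compound 2 to compound 3 (beyond the scatter) is expected to be modest, toward a lower number. Compound 3 is estimated at 70%, range 50% to 90%.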

Compound 3, a percentage reported as activity, at one concentration (the size of the read-out at that concentration, not a potency): 87%
For compound 3 the middle estimate is 17 percentage points below the measured one, and the stated range covers the measured number.
By their numbers in this assay, from the lowest: compound 1; then compounds 2 and 3 (each within the scatter of the next).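

In this assay, chloro in place of trifluoromethyl on the aromatic carbon gives a number 6 percentage points higher from compound 2 to compound 3 (within the scatter) and so does not separate the two groups at this position. Methyl in place of hydrogen on the oxygen gives a number 31 percentage points higher from compound 1 to compound 3 (beyond the scatter) and is the first single-place comparison to show a large step in this series. No available measurement accounts for either step.

Still open, on these data alone, is how a nitrile or an amine would read on that aromatic carbon, and how a longer chain would read on the oxygen. As far as these compounds go, whether the step at the oxygen carries over to the 4-chloro-3-(trifluoromethyl)phenyl group also remains open.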